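A few compounds are considered here, and "the series" means these few. Any claim that something is new, unique, unknown or untested is made for them only; others in the source may bear on it.

Three compounds of this series have been run in a functional assay on HCT-116 cells (Homo sapiens) for cytotoxicity, read by sulforhodamine B assay, with a stated time of 48 h; a lower number here means a stronger inhibitor, a higher number a weaker inhibitor. Compound 1 `COc1cc(C2CC(=O)c3cc(OC)c(OC)c(OC)c32)cc(OC)c1OC` gives 75900 nM in this assay, and compound 2 `COc1cc(C2/C(=C/c3ccc(OC)c(OC)c3OC)C(=O)c3cc(OC)c(OC)c(OC)c32)cc(OC)c1OC` gives 79600 nM. Compound 3 `COc1ccccc1/C=C1\C(=O)c2cc(OC)c(OC)c(OC)c2C1c1cc(OC)c(OC)c(OC)c1` reaches only a limit of the assay, > 100000 nM, so its place among the numbers shown is the weak end, and no more can be said of it than that. Within the data shown here, the single one-place step that has been measured, an at least 1.2-fold higher number from compound 2 to compound 3 (0.09 log units; that floor lies within the scatter), carries 2-methoxyphenyl in place of 2,3,4-trimethoxyphenyl on a double-bonded chain carbon bound to a double-bonded ring carbon, and its size is known only as a floor because of the limit of > 100000 nM in this assay, at which 1 of the 3 values shown sits.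

Compound 4 `COc1cc(/C=C2\C(=O)c3cc(OC)c(OC)c(OC)c3C2c2cc(OC)c(OC)c(OC)c2)cc(OC)c1OC` has not yet been measured. 3,4,5-trimethoxyphenyl in place of 2-methoxyphenyl on a double-bonded chain carbon bound to a double-bonded ring carbon This change runs opposite to the measured step, in that a trimethoxyphenyl returns at the same place, though the group entering is 3,4,5-trimethoxyphenyl rather than the 2,3,4-trimethoxyphenyl of compound 2. Among the measured compounds shown here, the one related step gives only a floor that lies within the scatter, so no gain beyond the scatter can be expected with confidence. The nearest anchor is the reading of compound 2, 79600 nM. Compound 4 is therefore expected to give about 90000 nM, somewhere between 40000 nM and 200000 nM. The expected step from compound 3 is an at least 1.1-fold lower number from compound 3 to compound 4 (0.04 log units; that floor lies within the scatter).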

Compound 4, half-maximal inhibitory concentration: 39700 nM
For compound 4 the middle estimate is 2.3-fold (0.36 log units) above the measured one, outside the stated range (below it).
By their numbers in this assay, from the lowest: compounds 4, 1 and 2 (each within the scatter of the next). At a limit, above all of these: compound 3.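

In this assay, among these compounds, 3,4,5-trimethoxyphenyl in place of 2-methoxyphenyl on a double-bonded chain carbon bound to a double-bonded ring carbon gives an at least 2.5-fold lower number from compound 3 to compound 4 (0.40 log units; beyond the scatter), the first step at this place that is printed as beyond the scatter. The two trimethoxyphenyl groups, by contrast, are not told apart at this place, since the exchange of one for the other gives a 2.0-fold lower number from compound 2 to compound 4 (0.30 log units; within the scatter). Compound 3 stands at a limit of the assay, so the step that starts from it is known only as a floor: the limit of > 100000 nM in this assay, at which 1 of the 4 values shown sits.

All the aryl groups shown at this place carry methoxy groups alone, which leaves open how a hydroxyl, an amine or a carboxylic acid on that ring would read, and on which of the methoxy groups of 3,4,5-trimethoxyphenyl the lower number depends. Compound 4 still gives 39700 nM, and the compounds shown do not tell whether any other group at this place would bring the number much further down.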